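Aryl swap on the thiophene-fused core: compound 3 outlook

The source may report more compounds than this note shows. Statements on the series, on what has been measured and on what is new or still open speak of the compounds shown alone.

Measured so far:
compound 1 `CN(C(=O)N1CC[C@H](n2cnc3cc(-c4ccc(Cl)cc4)sc3c2=O)C1)[C@H]1CCN(C2CCC2)C1` gives 1 nM in an assay on isolated protein for binding affinity to melanin-concentrating hormone receptor 1 (Homo sapiens); on this read-out lower numbers stand for stronger inhibition and higher numbers for weaker inhibition
compound 2 `CN1CC[C@H](N(C)C(=O)N2CC[C@H](n3cnc4cc(-c5ccc(OC(F)(F)F)cc5)sc4c3=O)C2)C1` gives 39 nM in this assay

Compound 2 stands at the higher of the two numbers; compound 1 gives the lower one, and no single-point step between them is shown. Compound 3 `CN1CC[C@H](N(C)C(=O)N2CC[C@H](n3cnc4cc(-c5ccc6c(c5)OCCO6)sc4c3=O)C2)C1` carries 2,3-dihydro-1,4-benzodioxin-6-yl in place of 4-(trifluoromethoxy)phenyl on an aromatic carbon. Within the data shown here, no measured pair covers this kind of exchange, so the step from compound 2 to compound 3 is expected to be small in this assay, without a clear direction beyond the scatter, as a 1.3-fold higher number from compound 2 to compound 3 (0.11 log units; within the scatter). Compound 3 is accordingly expected to give 50 nM, within 15 nM to 160 nM.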

Compound 3, inhibition constant: 143 nM
Compound 3: middle estimate off by 2.9-fold (0.46 log units), on the low side; the measured number falls inside the stated range.
By their numbers in this assay, from the lowest: compound 1; then compound 2; then compound 3.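

In this assay this position, on an aromatic carbon next to the ring sulfur, proves sensitive to the aryl group: 2,3-dihydro-1,4-benzodioxin-6-yl in place of 4-(trifluoromethoxy)phenyl gives a 3.7-fold higher number from compound 2 to compound 3 (0.56 log units; beyond the scatter) with the rest of the structure unchanged. Among these compounds, this is the first change confined to one place. Nothing at hand accounts for the step. Still open, as far as these compounds go, is how a pyridine ring or a methoxy group would compare at this position. From the compounds shown here alone, whether the step carries over to the structure of compound 1 also remains open.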